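A few compounds are considered here, and "the series" means these few. Any claim that something is new, unique, unknown or untested is made for them only; others in the source may bear on it.

Of the compounds shown here, two have been read so far in a functional assay on DU-145 cells (Homo sapiens) for inhibition, read by trypan blue exclusion, with a stated time of 96 h; a lower number here means a stronger inhibitor of growth, a higher number a weaker inhibitor of growth. Compound 1 (`O=C(/C(=C\c1ccc(O)c([N+](=O)[O-])c1)SCc1ccc(Cl)cc1)c1ccc(Cl)cc1`) gives 10000 nM and compound 2 (`O=C(/C(=C\c1c(O)cc(O)cc1O)S(=O)(=O)c1ccccc1Br)c1ccc(Cl)cc1`) gives 50000 nM as the higher of the two numbers, so compound 2 is the weaker inhibitor of growth, by a gap beyond the scatter. Compound 3 (`O=C(/C(=C\c1c(O)cc(O)cc1O)SCc1ccc(Cl)cc1)c1ccc(Cl)cc1`) differs from compound 2 in one place, as follows: (4-chlorobenzyl)sulfanyl in place of (2-bromophenyl)sulfonyl on a double-bonded chain carbon bound to a carbonyl carbon and a double-bonded chain carbon with (4-chlorobenzyl)sulfanyl in place of (2-bromophenyl)sulfonyl on a double-bonded chain carbon bound to a carbonyl carbon and a double-bonded chain carbon. Among the measured compounds shown here, no measured pair shows this change alone. For the measured compounds named here, compound 3 differs elsewhere from compound 1, which also carries (4-chlorobenzyl)sulfanyl, and as the only guide in this assay compound 1 gives 10000 nM. A fall in the number beyond the scatter is therefore expected, and the expected step is a 5.0-fold lower number from compound 2 to compound 3 (0.70 log units; beyond the scatter) in that direction. Compound 3 is estimated at 10000 nM with an expected range from 2500 nM to 40000 nM in this assay once measured.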

Compound 3, concentration for 50% growth inhibition: > 100000 nM
Compound 3: only a limit was reported; the forecaster's own chance of this, stated with the estimate: 10%; at least 10-fold (1.00 log units) between middle value and limit.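

In this assay compound 3 returns only a limit, > 100000 nM, so both steps that end at it are floors and not sizes: the limit of > 100000 nM in this assay, at which 1 of the 3 values shown sits. On the double-bonded chain carbon bound to a carbonyl carbon and a double-bonded chain carbon, (4-chlorobenzyl)sulfanyl in place of (2-bromophenyl)sulfonyl gives an at least 2.0-fold higher number from compound 2 to compound 3 (0.30 log units; that floor lies within the scatter), so with 2,4,6-trihydroxyphenyl held this change brings no fall in the number, though that floor alone does not establish a rise. With (4-chlorobenzyl)sulfanyl held, 2,4,6-trihydroxyphenyl in place of 4-hydroxy-3-nitrophenyl gives an at least 10-fold higher number from compound 1 to compound 3 (1.00 log units; beyond the scatter), so the reading of compound 1 does not carry over to the 2,4,6-trihydroxyphenyl series.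

Going by these compounds, the real size of both steps stays open. Also open, on these data alone, is whether an amine or a carboxylic acid on that chain carbon would lower the number with 2,4,6-trihydroxyphenyl retained.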